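Thiophene for methoxyphenyl in a weakly antiproliferative pair

The source may report more compounds than this note shows. Statements on the series, on what has been measured and on what is new or still open speak of the compounds shown alone.

Compound 1, `FC(F)(F)c1ccc(C2=NN(C(=S)Nc3ccccc3)C(c3ccc4c(c3)OCCO4)C2)cc1`, gives 112000 nM in a functional assay on HCT-116 cells (Homo sapiens) for antiproliferative activity, read by MTT assay, with a stated time of 48 h; on this read-out higher numbers stand for weaker inhibition of growth and lower numbers for stronger inhibition of growth.
Compound 2, `COc1ccccc1C1=NN(C(=S)Nc2ccccc2)C(c2ccc3c(c2)OCCO3)C1`, gives only a limit in this assay, > 200000 nM.

Compound 2 therefore stands at the weak end of the two values shown, sitting on (the limit of > 200000 nM in this assay, at which 1 of the 2 values shown sits). Compound 3, `S=C(Nc1ccccc1)N1N=C(c2cccs2)CC1c1ccc2c(c1)OCCO2`, differs from compound 2 by thiophen-2-yl in place of 2-methoxyphenyl on a carbon with a double bond to nitrogen. Going by the values given here, the one measured step that bears on a change on a carbon with a double bond to nitrogen is an at least 1.7-fold higher number from compound 1 to compound 2 (0.25 log units; that floor lies within the scatter), and it ended at the limit. Compound 3 is expected to remain weak, with the step of an at least 1.2-fold lower number from compound 2 to compound 3 (0.09 log units; that floor lies within the scatter) expected to lie within the scatter. Compound 3 is estimated at 160000 nM, with a range from 70000 nM to 300000 nM.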

Compound 3, concentration for 50% growth inhibition: 8190 nM
The estimate for compound 3 lay 20-fold (1.29 log units) above the measured number; measured number below the stated range.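

In this assay, the carbon with a double bond to nitrogen proved able to carry a large change: thiophen-2-yl brings an at least 24-fold lower number from compound 2 to compound 3 (1.38 log units; beyond the scatter) and a 14-fold lower number from compound 1 to compound 3 (1.14 log units; beyond the scatter). The earlier step between the two substituted phenyl groups had shown nothing of this size. The step from compound 2 gives only a floor, since compound 2 stands at a limit: the limit of > 200000 nM in this assay, at which 1 of the 3 values shown sits.

The compounds shown leave open whether this gain is particular to thiophen-2-yl or would also appear with furan-2-yl, pyridin-2-yl or unsubstituted phenyl at this place.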